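Compound 2 to compound 4: a step at the limit

The source may report more compounds than this note shows. Statements on the series, on what has been measured and on what is new or still open speak of the compounds shown alone.

Values in a functional assay on MCF7 cells (Homo sapiens) for antiproliferative activity, read by MTT assay, with a stated time of 72 h (a higher number here means a weaker inhibitor, a lower number a stronger inhibitor), so far, each one a limit of the assay and not a number:
- compound 1 `COc1ncc(-c2ccc3c(c2)N(c2ccc(F)cc2)C(=O)CO3)cc1NS(=O)(=O)c1ccc(F)cc1` gives > 40000 nM as a limit
- compound 2 `COc1cccc(N2C(=O)COc3ccc(-c4cccc(NS(=O)(=O)c5ccc(F)cc5)c4)cc32)c1` gives > 40000 nM as a limit
- compound 3 `O=C1COc2ccc(-c3cnc4ccccc4c3)cc2N1` gives > 40000 nM as a limit

Compound 2 stands at > 40000 nM in this assay and has only this limit to its name. Among the compounds with values here, the whole set so far comes down to the limit of > 40000 nM in this assay, at which 3 of the 3 values shown sit, so no measured compound offers a number to compare it with, and no measured pair gives a step to scale from.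

Compound 4 `Cc1ccc(N2C(=O)COc3ccc(-c4cccc(NS(=O)(=O)c5ccc(F)cc5)c4)cc32)cc1` differs from compound 2 in one place, (4-methylphenyl in place of 3-methoxyphenyl on an amide-type nitrogen in a ring), with 4-methylphenyl in place of 3-methoxyphenyl on an amide-type nitrogen in a ring. Compound 2 reads > 40000 nM as a limit, and that is the only anchor for the expectation. No shift beyond the usual scatter is expected in this assay, and no direction is favoured. The expected step of a number no higher from compound 2 to compound 4 (the limit leaves the size open) is an estimate made against a limit and not against a number. Compound 4 is most likely to be reported at the same limit, with an estimated value of 40000 nM and an expected range of 15000 nM to 40000 nM if a number is returned at all.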

Compound 4, half-maximal inhibitory concentration: 32100 nM
Beside the measured number, compound 4's estimate is 1.2-fold (0.10 log units) above it; low and high end bracket the measured number.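

In this assay, within the data shown here, compound 4 gives 32100 nM, the only actual number in the set so far. Compound 2 gives > 40000 nM, which is a limit of the assay. For the group on the amide-type nitrogen in a ring, 4-methylphenyl in place of 3-methoxyphenyl gives an at least 1.2-fold lower number from compound 2 to compound 4 (0.09 log units; that floor lies within the scatter), and only this floor can be stated, not the true size of the step, because the starting point is a limit: the limit of > 40000 nM in this assay, at which 3 of the 4 values shown sit.

Open, as far as these compounds go, is whether any group at this place can move this assay well away from the value of compound 4, for instance an amine on a longer chain or a phenyl ring carrying a carboxylic acid in place of the 4-methylphenyl. Also open, from the compounds shown here alone, is how much the other parts of the core contribute, since compound 1 and compound 3 each differ from compound 4 in more than one place and so give no comparison that can be read.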